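This account rests on a few compounds, and the source may have more. Where it says the series, first, only, none or still open, it means among the compounds named here.

In an ADME assay on HEK293 cells (Homo sapiens) for cytotoxicity, with a stated time of 72 h (a lower number here means that less compound is needed, a higher number that more compound is needed for the effect), compound 1 (`Cc1cc(NC(=O)Nc2ccc(C(C)(C)C)cc2)c2ccccc2n1`), which carries a tert-butyl group, gives > 25000 nM, a limit of the assay and not a number. Compound 2 (`Cc1cc(NC(=O)Nc2ccccc2OC(F)(F)F)c2ccccc2n1`) gives > 25000 nM, likewise a limit. Going by the values given here, the two measured compounds thus share (the limit of > 25000 nM in this assay, at which 2 of the 2 values shown sit), and no step between measured compounds is available. Compound 3 (`CCc1ccc(NC(=O)Nc2cc(C)nc3ccccc23)cc1`) has ethyl in place of tert-butyl on an aromatic carbon, para to a large group: ethyl in place of tert-butyl on an aromatic carbon. In this assay, no change beyond the usual scatter is expected in either direction, and the estimated step that the limit leaves unreadable from compound 1 to compound 3 is expected to be small. This expectation rests on compound 1, whose limit is > 25000 nM. A reading at that same limit is the likeliest outcome. For compound 3, the expected value is 28000 nM, with an estimated range from 14000 nM to 56000 nM.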

Compound 3, half-maximal effective concentration: 16000 nM
Compound 3: the middle estimate sits 1.8-fold (0.24 log units) above what was measured, within the range that was stated.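

Compound 3 brings the first reading in this assay that is a number and not a limit, so the series shown is no longer flat at the top of the assay. For ethyl in place of tert-butyl on an aromatic carbon, para to a large group, the result gives an at least 1.5-fold lower number from compound 1 to compound 3 (0.19 log units; that floor lies within the scatter). This is only a floor, so the change is not shown to go beyond the scatter, and the ceiling of the assay still governs most of what can be read: the limit of > 25000 nM in this assay, at which 2 of the 3 values shown sit.

On these data alone, how far the true distance from compound 1 lies beyond that floor remains open. So does the reading at this same place with a shorter chain, a longer chain, an amine or a carboxylic acid in place of ethyl.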